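The compounds below may be only part of what the source reports. "The series", "measured", "known", "first", "only" and "open" are said of these compounds alone.

Compound 1 `CCc1ccc(NS(=O)(=O)c2ccc(N3CCNC3=O)cc2)cc1`: 810 nM
Compound 2 `CCc1cccc(NS(=O)(=O)c2ccc(N3CCNC3=O)cc2)c1`: 130 nM
Compound 3 `O=C1NCCN1c1ccc(S(=O)(=O)Nc2ccc(Cl)cc2)cc1`: not yet measured

In a functional assay on MCF7 cells (Homo sapiens) for antiproliferative activity, read by sulforhodamine B assay, with a stated time of 48 h (a higher number here means a weaker inhibitor, a lower number a stronger inhibitor), compound 2 has the lower of the two numbers, at 130 nM. Compound 3 carries 4-chlorophenyl in place of 3-ethylphenyl on a sulfonamide nitrogen. Among the compounds with values here, the only measured step bearing on this is a 6.2-fold lower number from compound 1 to compound 2 (0.79 log units; beyond the scatter), with 3-ethylphenyl in place of 4-ethylphenyl. Within the data shown here, that is a single pair, and no 4-chlorophenyl compound has been measured, so the guidance is loose. By analogy with 4-ethylphenyl, a step of comparable size towards a higher number is expected in this assay. The expected step is a 4.6-fold higher number from compound 2 to compound 3 (0.66 log units; beyond the scatter). Compound 3 is estimated at 600 nM, with an expected range of 150 nM to 2400 nM.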

Compound 3, half-maximal inhibitory concentration: 170 nM
Estimate against measurement, compound 3: 3.5-fold (0.55 log units) above; the range from low to high includes it.
By their numbers in this assay, from the lowest: compounds 2 and 3 (each within the scatter of the next); then compound 1.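

In this assay, 4-chlorophenyl on the sulfonamide nitrogen stands level with 3-ethylphenyl (a 1.3-fold higher number from compound 2 to compound 3 (0.12 log units; within the scatter)). With chloro in place of ethyl on an aromatic carbon, the number falls (a 4.8-fold lower number from compound 1 to compound 3 (0.68 log units; beyond the scatter)), so the weaker value of compound 1 belongs to 4-ethylphenyl and does not extend to 4-chlorophenyl. No measurement here accounts for either step.

Still open, on these data alone, is how a methoxy group or an amine in place of chloro would read. Also open, as far as these compounds go, is whether a saturated cyclohexyl group on the sulfonamide nitrogen would keep these values.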